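The source may report more compounds than this note shows. Statements on the series, on what has been measured and on what is new or still open speak of the compounds shown alone.

Measured in a functional assay on IGROV-1 cells (Homo sapiens) for inhibition, read by sulforhodamine B assay, with a stated time of 48 h; on this read-out higher numbers stand for weaker inhibition of growth and lower numbers for stronger inhibition of growth:
- compound 1 `N#Cc1c(-c2nnc(O)c3nn(-c4ccccc4)cc23)nn(-c2ccccc2)c1-c1ccccc1`: 92200 nM
- compound 2 `N#Cc1c(-c2nnc(O)c3nn(-c4ccc(Cl)cc4)cc23)nn(-c2ccccc2)c1-c1ccccc1`: 91300 nM
- compound 3 `N#Cc1c(-c2nnc(-c3nn(-c4ccccc4)c(-c4ccccc4)c3C#N)c3nn(-c4ccccc4)cc23)nn(-c2ccccc2)c1-c1ccccc1`: 13300 nM

Compound 3, at 13300 nM, has the lowest number of the three in this assay, and the gap to each of the other two lies beyond the usual scatter. Compound 4 `N#Cc1c(-c2nnc(-c3nn(-c4ccccc4)c(-c4ccccc4)c3C#N)c3nn(-c4ccc(Cl)cc4)cc23)nn(-c2ccccc2)c1-c1ccccc1` has not yet been measured. It differs from compound 3 by a single change, chloro in place of hydrogen on an aromatic carbon, turning phenyl into 4-chlorophenyl.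

Within the data shown here, only one measured step bears on this change. The same replacement gave a 1.0-fold lower number from compound 1 to compound 2 (0.00 log units; within the scatter), which lies within the scatter. That evidence comes from a single pair of smaller compounds, so it may not carry over fully, but it gives no reason to expect a shift in either direction. No step beyond the scatter is therefore expected. The expected step is a 1.0-fold lower number from compound 3 to compound 4 (0.01 log units; within the scatter). For compound 4 the estimated value is 13000 nM, with an expected range from 6000 nM to 28000 nM.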

Compound 4, concentration for 50% growth inhibition: 98000 nM
Estimate against measurement, compound 4: 7.5-fold (0.88 log units) below; the whole stated range lies below it.
By their numbers in this assay, from the lowest: compound 3; then compounds 2, 1 and 4 (each within the scatter of the next).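

In this assay the change from phenyl to 4-chlorophenyl is not silent at this position, as the earlier pair had suggested: here it gives a 7.4-fold higher number from compound 3 to compound 4 (0.87 log units; beyond the scatter). The effect of this chloro therefore depends on the compound that carries it: the same change on two cores in this assay, a 1.0-fold lower number (0.00 log units; within the scatter) from compound 1 to compound 2 and a 7.4-fold higher number (0.87 log units; beyond the scatter) from compound 3 to compound 4, 7.4-fold (0.87 log units) apart, beyond the scatter of two such steps. The lower number that set compound 3 apart does not survive the change, and compound 4 stands within the scatter of compound 1.

The compounds shown carry only hydrogen or chloro at this place, so they leave open whether the step belongs to chloro itself or would also follow from a fluoro, a methoxy or an amine there. With one pair on each core, they also cannot tell which feature of the core of compound 3 makes the position respond.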